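This account rests on a few compounds, and the source may have more. Where it says the series, first, only, none or still open, it means among the compounds named here.

Measured compounds:
Compound 1, `CC(=O)OC[C@H]1O[C@H](OC[C@@H](Cn2cc(CN(c3nc(-c4ccc(Cl)cc4)no3)C3CCCCC3)nn2)OC(C)=O)C=C[C@@H]1OC(C)=O`: 46.9 ug/mL
Compound 2, `CC(=O)OC[C@H]1O[C@H](OC[C@@H](Cn2cc(CN(c3nc(-c4ccc(Br)cc4)no3)C3CCCCC3)nn2)OC(C)=O)C=C[C@@H]1OC(C)=O`: 47.6 ug/mL

In an ADME assay on HepG2 cells (Homo sapiens) for cytotoxicity, read by MTT assay, with a stated time of 48 h (a lower number here means that less compound is tolerated, a higher number that more compound is tolerated), compound 2 stands alongside compound 1; the two numbers lie within the usual scatter of each other, so neither can be called better tolerated than the other. Within the data shown here, the single measured step, a 1.0-fold higher number from compound 1 to compound 2 (0.01 log units; within the scatter), shows that exchanging one halogen for another on that aromatic carbon left the read-out essentially unchanged.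

Compound 3, `CC(=O)OC[C@H]1O[C@H](OC[C@@H](Cn2cc(CN(c3nc(-c4ccc(C(F)(F)F)cc4)no3)C3CCCCC3)nn2)OC(C)=O)C=C[C@@H]1OC(C)=O`, is the next compound in this series. It differs from compound 2 in one place: trifluoromethyl in place of bromo on an aromatic carbon. The step bearing on this change is the only one measured, a 1.0-fold higher number from compound 1 to compound 2 (0.01 log units; within the scatter), which was flat. Among the measured compounds shown here, no measured step involves a trifluoromethyl group, so the data give no direct guide to it; what they do show is that the substituent at this position has not moved the number so far. On that basis the step from compound 2 to compound 3 is expected to stay within the scatter, a 1.1-fold lower number from compound 2 to compound 3 (0.02 log units; within the scatter). Compound 3 is therefore estimated at 45 ug/mL, with a range from 24 ug/mL to 85 ug/mL.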

Compound 3, half-maximal cytotoxic concentration: 81.4 ug/mL
The estimate for compound 3 lay 1.8-fold (0.26 log units) below the measured number; the range from low to high includes it.
By their numbers in this assay, from the lowest: compounds 1, 2 and 3 (each within the scatter of the next).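

In this assay, the change from bromo to trifluoromethyl gives a 1.7-fold higher number from compound 2 to compound 3 (0.23 log units; within the scatter), and the change from chloro to trifluoromethyl gives a 1.7-fold higher number from compound 1 to compound 3 (0.24 log units; within the scatter). The earlier compounds shown here showed only one halogen exchanged for another, whereas these steps replace a single halogen atom with a group of several atoms, and the number still stays within the usual scatter. Across the three compounds, therefore, this place on the six-membered aromatic ring has carried chloro, bromo and trifluoromethyl without any step that can be told apart from repeat-measurement noise, and nothing available here offers an explanation for the numbers.

What the compounds shown leave open is whether a group of a different kind at this position, such as an amine, a carboxylic acid or a longer alkyl chain, would produce a step beyond the scatter. They also leave open whether changes elsewhere on the shared core would move the number in this assay, since all three compounds differ only at this one place.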